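The source may hold more compounds than are shown below. What is called first, only, known or untested is meant among the compounds shown, and "the series" means these compounds.

Of the compounds shown here, two with the shared core have been measured in a functional assay for inhibition, with Rattus norvegicus as the target; a higher number here means a weaker inhibitor, a lower number a stronger inhibitor. Compound 1 `CC(/N=c1\c(O)c(O)\c1=N/c1cccc2cccnc12)C(C)(C)C` gives 8100 nM in this assay. Compound 2 `CC(C)(C)/N=c1\c(O)c(O)\c1=N/c1ccc(C#N)cc1` gives 560 nM in this assay, the lower of the two numbers; the gap between compound 2 and compound 1 lies beyond the usual scatter, so compound 2 is the stronger inhibitor of the pair. Compound 3 `C[C@@H](/N=c1\c(O)c(O)\c1=N/c1ccc(C#N)cc1)C1CCCCC1` has not yet been measured in this assay. It differs from compound 2 in one place: 1-cyclohexylethyl in place of tert-butyl on a double-bonded nitrogen. Going by the values given here, no pair of measured compounds differing in only one place is available, so the size of this step cannot be read from the data. Compound 3 is expected to stay close to compound 2, with the step of a 1.6-fold higher number from compound 2 to compound 3 (0.21 log units; within the scatter) in this assay expected to fall within the scatter or slightly towards a weaker inhibitor. The estimate for compound 3 in this assay is 900 nM, with a range from 250 nM to 3500 nM.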

Compound 3, half-maximal inhibitory concentration: 2600 nM
Compound 3: the middle estimate sits 2.9-fold (0.46 log units) below what was measured; low and high end bracket the measured number.
By their numbers in this assay, from the lowest: compound 2; then compound 3; then compound 1.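

In this assay, this position on the double-bonded nitrogen proves sensitive to the group it carries: 1-cyclohexylethyl in place of tert-butyl gives a 4.6-fold higher number from compound 2 to compound 3 (0.67 log units; beyond the scatter), a modest move towards a weaker inhibitor that lies beyond the scatter. Going by these compounds alone, this is the first single change that can be read. It also shows that a group of 8 heavy atoms with a six-membered non-aromatic ring and a defined stereocentre still leaves compound 3 with a measurable inhibition of 2600 nM. Nothing in the available data accounts for this step.

The compounds shown leave open whether the ring, the branching or the stereocentre matters most for the step. They also leave open how a plain cyclohexyl group, the opposite stereoisomer or a chain carrying an amine would behave on this nitrogen.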